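The source may hold more compounds than are shown below. What is called first, only, known or untested is meant among the compounds shown, and "the series" means these compounds.

Compound 2 `C#CCCn1c(Cc2cc(OC)c(OC)c(OC)c2)nc2c(N)nc(F)nc21` and compound 1 `C=CCCCn1c(Cc2cc(OC)c(OC)c(OC)c2)nc2c(N)nc(F)nc21` share one core and differ only in the chain attached to it. In a functional assay on MCF7 cells (Homo sapiens) for antiproliferative activity (on this read-out higher numbers stand for weaker inhibition and lower numbers for stronger inhibition), compound 1 gives 44700 nM, and compound 2 gives 25100 nM, the lower of the two numbers, though the step of a 1.8-fold lower number from compound 1 to compound 2 (0.25 log units; within the scatter) lies within the usual scatter, so the two compounds are not really told apart. Compound 3 `CC#CCCn1c(Cc2cc(OC)c(OC)c(OC)c2)nc2c(N)nc(F)nc21` is reached from compound 2 by a single change: methyl in place of hydrogen on a triple-bonded carbon. Among the measured compounds shown here, no measured pair shows this exact change. For the measured compounds named here, the one step that bears on it, a 1.8-fold lower number from compound 1 to compound 2 (0.25 log units; within the scatter), reshaped the same chain and moved the number only a little, so a further change at the triple-bonded carbon is expected to leave this assay largely where it stands. Compound 3 is therefore expected to give about 25000 nM in this assay, most likely between 9000 nM and 70000 nM, a step of a 1.0-fold lower number from compound 2 to compound 3 (0.00 log units; within the scatter) that is expected to stay within the scatter.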

Compound 3, half-maximal inhibitory concentration: 37200 nM
For compound 3 the middle estimate is 1.5-fold (0.17 log units) below the measured one; the measured number falls inside the stated range.
By their numbers in this assay, from the lowest: compounds 2, 3 and 1 (each within the scatter of the next).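

In this assay, methyl in place of hydrogen on a triple-bonded carbon gives a 1.5-fold higher number from compound 2 to compound 3 (0.17 log units; within the scatter) and so does not set the two compounds apart, which shows that this end of the chain accepts one added carbon without a step beyond the scatter. The exchange of allyl for prop-1-yn-1-yl on the same chain gives a 1.2-fold lower number from compound 1 to compound 3 (0.08 log units; within the scatter) and likewise does not separate the two compounds, so the three chain ends shown cannot be told apart in this assay. No evidence is at hand to explain this result. On these data alone, whether a larger group on the triple-bonded carbon, such as an amine, a hydroxymethyl or a longer chain, would give a step beyond the scatter remains open. So does whether a chain ending in a carboxylic acid would do so.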